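The source may hold more compounds than are shown below. What is called first, only, known or untested is meant among the compounds shown, and "the series" means these compounds.

Of the compounds shown here, three from one series have been measured in a functional assay for inhibition, with Homo sapiens as the target; on this read-out lower numbers stand for stronger inhibition and higher numbers for weaker inhibition. Compound 1, `c1csc(-c2ccnc(Nc3ccc(-n4ccnc4)cc3)n2)c1`, gives 4300 nM. Compound 2, `c1cc(-c2ccnc(Nc3ccc(-n4ccnc4)cc3)n2)ccn1`, gives 7600 nM. Compound 3, `c1ccc(Nc2nccc(-c3ccncc3)n2)cc1`, gives 900 nM; it stands lowest of the three, with compound 1 nearest and compound 2 furthest. Of the measured pairs, the step of an 8.4-fold lower number from compound 2 to compound 3 (0.93 log units; beyond the scatter) is the larger, while the step of a 1.8-fold lower number from compound 2 to compound 1 (0.25 log units; within the scatter) is the smaller. That latter change, (thiophen-2-yl in place of pyridin-4-yl on an aromatic carbon), is now made again from compound 3 to compound 4, `c1ccc(Nc2nccc(-c3cccs3)n2)cc1`, whose result is not yet known; the difference between compound 3 and compound 4 is thiophen-2-yl in place of pyridin-4-yl on an aromatic carbon. The two cores differ by hydrogen in place of 1H-imidazol-1-yl on an aromatic carbon. Around the place, the change in compound 3 is meta to a group of 7 heavy atoms, whereas in compound 2 it was meta to a large group, so it is the same kind of change rather than the same one. The expected step for compound 4 is a 1.4-fold lower number from compound 3 to compound 4 (0.14 log units; within the scatter). That expectation rests on compound 3 at 900 nM and on the earlier step of a 1.8-fold lower number from compound 2 to compound 1 (0.25 log units; within the scatter), which lay within the scatter. The estimate for compound 4 in this assay is therefore 650 nM, between 250 nM and 1800 nM.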

Compound 4, half-maximal inhibitory concentration: 31700 nM
Compound 4: the middle estimate sits 49-fold (1.69 log units) below what was measured, and the stated range ends below it.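

In this assay, thiophen-2-yl in place of pyridin-4-yl gives a 35-fold higher number from compound 3 to compound 4 (1.55 log units; beyond the scatter), so the change does not carry over from one core to the other: the same change on two cores in this assay, a 1.8-fold lower number (0.25 log units; within the scatter) from compound 2 to compound 1 and a 35-fold higher number (1.55 log units; beyond the scatter) from compound 3 to compound 4, 62-fold (1.79 log units) apart, beyond the scatter of two such steps

Hydrogen in place of 1H-imidazol-1-yl, read on the thiophen-2-yl compounds, gives a 7.4-fold higher number from compound 1 to compound 4 (0.87 log units; beyond the scatter), and this too differs from its earlier size on the pyridin-4-yl compounds: the same change on two cores in this assay, an 8.4-fold lower number (0.93 log units; beyond the scatter) from compound 2 to compound 3 and a 7.4-fold higher number (0.87 log units; beyond the scatter) from compound 1 to compound 4, 62-fold (1.79 log units) apart, beyond the scatter of two such steps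

Both comparisons rest on the same four compounds, so they show a single dependence of each change on the other, not two separate findings; they show that a step read on one core was no guide on the other here, but not why, nor whether this holds beyond this pair of cores.

From the compounds shown here alone, it remains open whether a methoxy group or an amine in place of 1H-imidazol-1-yl would behave like hydrogen or like 1H-imidazol-1-yl. Going by these compounds, it is equally open where a phenyl or a furan-2-yl group in place of pyridin-4-yl would fall on each core.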